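Three limits and one open question on a shorter side chain

A few compounds are considered here, and "the series" means these few. Any claim that something is new, unique, unknown or untested is made for them only; others in the source may bear on it.

Compound 1 `C/N=C(/NC#N)NCCCn1nc(-c2ccccc2)ccc1=O` gives > 100 mg/kg in a functional assay on the whole organism (stomach) with Rattus norvegicus as the target (on this read-out lower numbers stand for an effect already at smaller amounts and higher numbers for an effect only at larger amounts of compound), which is a limit of the measurement and not a number.
Compound 2 `N#CNC(=N)NCCCCCn1nc(-c2ccccc2)ccc1=O` gives > 100 mg/kg in this assay, again a limit.
Compound 3 `C=CCNC(=S)NCCCCn1nc(-c2ccccc2)ccc1=O` gives > 100 mg/kg in this assay, also a limit.

Compound 3 therefore stands where every measured compound stands: at the limit (the limit of > 100 mg/kg in this assay, at which 3 of the 3 values shown sit). The step from compound 3 to compound 4 `C/N=C(\S)NCCCn1nc(-c2ccccc2)ccc1=O` is a group of 5 heavy atoms (2 carbon, 2 nitrogen, 1 sulfur; no ring) in place of a group of 8 heavy atoms (5 carbon, 2 nitrogen, 1 sulfur; no ring), on a saturated chain carbon, three bonds along the chain from an aromatic nitrogen. The measured steps that touch the same chain position are a step that the two limits leave unreadable from compound 1 to compound 3 and a step that the two limits leave unreadable from compound 1 to compound 2, and the remaining pair gives a step that the two limits leave unreadable from compound 2 to compound 3; none of them can be read as a size or a direction, since both ends sit at the limit. Among the measured compounds shown here, no measured step shows a change beyond the scatter in this assay, so no direction can be expected with confidence. Compound 4 is estimated at 150 mg/kg, with a range from 50 mg/kg to 500 mg/kg. The expected step is a step that the limit leaves unreadable from compound 3 to compound 4, most likely ending again at a limit.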

Compound 4, dose for half-maximal effect: > 100 mg/kg
Compound 4: a limit, no number; the forecaster's own chance of this, stated with the estimate: 75%; the middle value is on the limit's open side.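

Compound 4 also ends at a limit, so its steps from compound 1, compound 2 and compound 3 cannot be read as a size or a direction: the limit of > 100 mg/kg in this assay, at which 4 of the 4 values shown sit. In this assay the compounds shown leave open which side chain, if any, would give a readable number.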